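The source may hold more compounds than are shown below. What is called first, only, known or untested is meant among the compounds shown, and "the series" means these compounds.

Measured so far in an assay on isolated protein for inhibition of Nicotinamide phosphoribosyltransferase (Homo sapiens), read by WST assay, with stated times of 60 min, 5 min and 30 min, in the presence of a further agent that is not named here; a higher number here means a weaker inhibitor, a lower number a stronger inhibitor:
- compound 1, `O=C(/C=C/c1cccnc1)NCCCCCc1cccc(S(=O)(=O)Nc2ccccc2)c1`: 16.5 nM
- compound 2, `O=C(/C=C/c1cccnc1)NCCCCCCc1cccc(S(=O)(=O)Nc2ccccc2)c1`: 10.5 nM
- compound 3, `O=C(/C=C/c1cccnc1)NCCCCCCCc1cccc(S(=O)(=O)Nc2ccccc2)c1`: 31.3 nM

Compound 2 sits at the low end of these three numbers, yet compound 1 lies within the scatter of it, so the two cannot be ranked; compound 3 alone gives a higher number beyond the scatter. Compound 4, `Cc1ccc(C)c(NS(=O)(=O)c2cccc(CCCCCCNC(=O)/C=C/c3cccnc3)c2)c1`, is not yet measured. It differs from compound 2 by 2,5-dimethylphenyl in place of phenyl on a sulfonamide nitrogen. Going by the values given here, no measured pair varies this part of the molecule, so the direction of the step is open. A small step is expected, with the number for compound 4 estimated to stay within the scatter of compound 2, as a 1.2-fold higher number from compound 2 to compound 4 (0.09 log units; within the scatter). The expected value for compound 4 in this assay is 13 nM, between 4 nM and 45 nM.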

Compound 4, half-maximal inhibitory concentration: 11.6 nM
Compound 4: middle estimate off by 1.1-fold (0.05 log units), on the high side, within the range that was stated.
By their numbers in this assay, from the lowest: compounds 2, 4, 1 and 3 (each within the scatter of the next, the first and the last beyond it).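

In this assay, the step of a 1.1-fold higher number from compound 2 to compound 4 (0.04 log units; within the scatter) comes with 2,5-dimethylphenyl in place of phenyl on a sulfonamide nitrogen, so this position accepts the added methyl groups without a readable change. The earlier compounds shown here varied only the chain, leaving this part of the molecule untested. No measurement at hand accounts for this result.

Going by these compounds, it remains open whether this tolerance extends to other groups here, such as a pyridine ring, a carboxylic acid or an amine. Also open, on these data alone, is whether it holds on the shorter and longer chains.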